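The source may report more compounds than this note shows. Statements on the series, on what has been measured and on what is new or still open speak of the compounds shown alone.

Measured so far:
- compound 1, `COc1ccc(-c2cc(-c3ccc(S(N)(=O)=O)cc3)cnc2N)cn1`: > 100 ug/mL
- compound 2, `COc1ccc(-c2cc(-c3ccc4nccn4c3)cnc2N)cn1`: > 100 ug/mL

Of the compounds shown here, two with a shared core have been measured in a physicochemical assay for solubility, read by nephelometry, measured as kinetic solubility, at pH 2; a higher number here means a more soluble compound, a lower number a less soluble compound. For compound 1 the reading of > 100 ug/mL is a limit of the assay rather than a number. For compound 2 the reading of > 100 ug/mL is likewise a limit. Compound 1 therefore stands at the upper end of what this assay reports, and because the limit of > 100 ug/mL in this assay, at which 2 of the 2 values shown sit, nothing finer can be said about where it sits against compound 2.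

Compound 3, `COc1ccc(-c2cc(-c3ccc(C(=O)N(C)C)cc3)cnc2N)cn1`, is not yet measured. It differs from compound 1 in one place: dimethylcarbamoyl in place of sulfamoyl on an aromatic carbon. Among the measured compounds shown here, no measured pair of compounds in this set carries a comparable change, so there is no direct guide to the size of the step from compound 1 to compound 3 in this assay.

Given that compound 1 already sits at the limit, compound 3 is expected to stay close to that limit, with an estimated step of a number no higher from compound 1 to compound 3 (the limit leaves the size open). The estimate for compound 3 in this assay is 100 ug/mL, within a range from 40 ug/mL to 200 ug/mL.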

Compound 3, solubility: > 100 ug/mL
Compound 3: no number, only a limit; the forecaster's own chance of this, stated with the estimate: 60%; the middle value sits exactly at the limit.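

No step from compound 1 to compound 3 can be read in this assay, because the readings of both compounds are limits and not numbers: the limit of > 100 ug/mL in this assay, at which 3 of the 3 values shown sit.

The compounds shown leave open whether dimethylcarbamoyl in place of sulfamoyl on an aromatic carbon shifts the solubility at all, and by how much.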